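Methoxy for Fluoro in a Cytotoxicity Series

This account rests on a few compounds, and the source may have more. Where it says the series, first, only, none or still open, it means among the compounds named here.

Three compounds measured in an ADME assay on Huh-7 cells (Homo sapiens) for cytotoxicity; a lower number here means a stronger inhibitor, a higher number a weaker inhibitor:

compound 1, `CN(c1cc2ncc(=O)[nH]c2cc1NC(=S)Nc1ccccc1)C1CCCCC1`, gives 49600 nM
compound 2, `COc1ccc(CNC(=N)Nc2cc3[nH]c(=O)cnc3cc2N(C)C2CCCCC2)cc1`, gives 19500 nM
compound 3, `CN(c1cc2ncc(=O)[nH]c2cc1Nc1nc(-c2ccc(F)cc2)cs1)C1CCCCC1`, gives 9920 nM

Compound 3 and compound 2 sit within the scatter of each other in this assay, so no order between them can be read; compound 1 stands beyond the scatter, with the higher number. Compound 4, `COc1ccc(-c2csc(Nc3cc4[nH]c(=O)cnc4cc3N(C)C3CCCCC3)n2)cc1`, has not yet been measured. It differs from compound 3 in one place: methoxy in place of fluoro on an aromatic carbon. Among the measured compounds shown here, no measured pair shows this change, so the step from compound 3 to compound 4 in this assay is expected to be small, in either direction, and not beyond the scatter, as a 1.0-fold higher number from compound 3 to compound 4 (0.00 log units; within the scatter). Compound 4 is therefore expected to give about 10000 nM, within a range from 4000 nM to 25000 nM.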

Compound 4, half-maximal inhibitory concentration: 15000 nM
Beside the measured number, compound 4's estimate is 1.5-fold (0.18 log units) below it; low and high end bracket the measured number.
By their numbers in this assay, from the lowest: compounds 3, 4 and 2 (each within the scatter of the next); then compound 1.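

In this assay the series now has its first step that can be read at a single place, a 1.5-fold higher number from compound 3 to compound 4 (0.18 log units; within the scatter) with methoxy in place of fluoro. Among the compounds shown here, at this position, para to a large group, going from 4-fluorophenyl to 4-methoxyphenyl does not carry the number beyond the scatter, something the earlier compounds, which differ in more than one place, could not show. Nothing measured here bears on the reason for this. A single pair cannot say how an amine, a carboxylic acid or a longer chain would behave on this carbon.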